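The source may report more compounds than this note shows. Statements on the series, on what has been measured and on what is new or still open speak of the compounds shown alone.

In a functional assay on HL60/A cells (Homo sapiens) for cytotoxicity, read by flow cytometry and annexin V staining, with a stated time of 18 h (a lower number here means a stronger inhibitor, a higher number a weaker inhibitor), compound 1 `C=C1C(=O)O[C@@H]2C=C(CCC(C)=O)[C@@H](C)CC[C@@H]12` reaches only the limit > 50000 nM, so no number is known for it. Among the compounds with values here, compound 2 `C/C1=C\CC[C@@]2(C)O[C@@H]2[C@H]2OC(=O)[C@@H](CN=[N+]=[N-])[C@@H]2CC1` gives 5900 nM in this assay and is the only measured compound with a true number. The other value, that of compound 1, is a limit (the limit of > 50000 nM in this assay, at which 1 of the 2 values shown sits). Compound 3 `C/C1=C\CC[C@@]2(C)O[C@@H]2[C@H]2OC(=O)[C@@H](Cn3cc(CO)nn3)[C@@H]2CC1` differs from compound 2 by 4-(hydroxymethyl)-1H-1,2,3-triazol-1-yl in place of azido on a saturated chain carbon bound to a saturated ring carbon. Within the data shown here, since no measured step of this kind exists, the step from compound 2 to compound 3 is only an expectation, a 1.5-fold higher number from compound 2 to compound 3 (0.18 log units; within the scatter), guessed to be a modest loss. Compound 3 is therefore estimated at 9000 nM, within 2500 nM to 35000 nM.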

Compound 3, half-maximal inhibitory concentration: > 100000 nM
Compound 3: no number, only a limit (the forecaster's own chance of this, stated with the estimate: 25%); at least 11-fold (1.04 log units) between middle value and limit.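

At this place, on a saturated chain carbon bound to a saturated ring carbon, the shown compounds now offer their first one-place comparison, and in this assay swapping azido for 4-(hydroxymethyl)-1H-1,2,3-triazol-1-yl gives an at least 16-fold higher number from compound 2 to compound 3 (1.22 log units; beyond the scatter). So this place does not accept every group, and the activity of compound 2 is not kept. The value of compound 3 is not a true number but a limit: the limit of > 100000 nM in this assay, at which 1 of the 3 values shown sits.

From the compounds shown here alone, it remains open whether the loss follows the triazole ring itself or its hydroxymethyl group. Going by these compounds, it also remains open whether a simple amine in place of azido would keep the activity.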